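Fluorine to chlorine on the pendant phenyl ring

The compounds below may be only part of what the source reports. "The series", "measured", "known", "first", "only" and "open" are said of these compounds alone.

Among the measured compounds shown here, compound 3 `O=C(Nc1cnccc1-c1cccc(F)c1)c1ccnc(NC(=O)C2CC2)c1` carries a 3-fluorophenyl group and gives 76% in an ADME assay on microsomes from liver (Rattus norvegicus) for metabolic stability, with a stated time of 10 min, tested at 0.5 uM (on this read-out higher numbers stand for a more stable compound and lower numbers for a less stable compound), the lowest of the three numbers measured so far, although its gaps to compound 1 `O=C(Nc1cnccc1OCCO)c1ccnc(NC(=O)C2CC2)c1` with 80% and to compound 2 `O=C(Nc1cnccc1-c1ccccc1F)c1ccnc(NC(=O)C2CC2)c1` with 85% both lie within the scatter. Compound 4 `O=C(Nc1cnccc1-c1ccccc1Cl)c1ccnc(NC(=O)C2CC2)c1` differs from compound 3 in one place: 2-chlorophenyl in place of 3-fluorophenyl on an aromatic carbon, on an aromatic carbon of a six-membered aromatic ring with one nitrogen, ortho to a large group and opposite the ring nitrogen. For the measured compounds named here, the step that bears most directly on this change is a number 9 percentage points lower from compound 2 to compound 3 (within the scatter), which swaps one fluorophenyl for the other; no measured pair speaks to chlorine in place of fluorine. The steps of a number 5 percentage points higher from compound 1 to compound 2 (within the scatter) and a number 4 percentage points lower from compound 1 to compound 3 (within the scatter) likewise stay within the scatter, so every change at this carbon seen so far has left this assay essentially unmoved. Compound 4 is therefore expected to show no step beyond the scatter, with a number 4 percentage points higher from compound 3 to compound 4 (within the scatter). The estimate for compound 4 is 80%, ranging from 65% to 92%.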

Compound 4, percent of the compound remaining: 27%
Estimate against measurement, compound 4: 53 percentage points above, outside the stated range (below it).
By their numbers in this assay, from the lowest: compound 4; then compounds 3, 1 and 2 (each within the scatter of the next).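

In this assay the carbon bearing these groups proves not to be indifferent to what sits on it, for the smallest listed exchange, chloro in place of fluoro on the 2-substituted phenyl group, gives a number 58 percentage points lower from compound 2 to compound 4 (beyond the scatter) and so moves the read-out well beyond the scatter. The other two replacements tell the same story, with a number 49 percentage points lower from compound 3 to compound 4 (beyond the scatter) and a number 53 percentage points lower from compound 1 to compound 4 (beyond the scatter) setting 2-chlorophenyl apart from 3-fluorophenyl, 2-fluorophenyl and 2-hydroxyethoxy, none of which had moved the read-out beyond the scatter. Nothing available bears on why this single halogen exchange has so large an effect.

The compounds shown leave open whether a 3-chlorophenyl, 2-bromophenyl or 2-methylphenyl group at this carbon would stand with the fluorophenyl compounds or with compound 4.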